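A methyl-to-dimethoxy swap on the benzyl amide

A few compounds are considered here, and "the series" means these few. Any claim that something is new, unique, unknown or untested is made for them only; others in the source may bear on it.

Three measured compounds share one core and differ only in the group on the amide nitrogen. For compound 1 `COc1cc(-c2nnc(SCC(=O)Nc3ccccc3C)n2N)cc(OC)c1OC` the reading in a functional assay on PC-3 cells (Homo sapiens) for antiproliferative activity, read by MTT assay, with a stated time of 48 h (on this read-out lower numbers stand for stronger inhibition and higher numbers for weaker inhibition), is a limit of the assay rather than a number, > 100000 nM. Compound 2 `COc1cc(-c2nnc(SCC(=O)Nc3ccc(C)cc3)n2N)cc(OC)c1OC` gives 43100 nM in this assay, and compound 3 `COc1cc(-c2nnc(SCC(=O)NCc3ccc(C)cc3)n2N)cc(OC)c1OC` gives 92800 nM. Moving the methyl on the phenyl ring brought an at least 2.3-fold lower number from compound 1 to compound 2 (0.36 log units; beyond the scatter), while the benzyl analogue gave an at least 1.0-fold lower number from compound 1 to compound 3 (0.03 log units; that floor lies within the scatter). Between the two numbered compounds, the added chain carbon gave a 2.2-fold higher number from compound 2 to compound 3 (0.33 log units; beyond the scatter), so compound 3 stands as the higher of the two numbers, with compound 2 its nearest neighbour.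

Compound 4 `COc1ccc(CNC(=O)CSc2nnc(-c3cc(OC)c(OC)c(OC)c3)n2N)cc1OC` arises from compound 3 by 3,4-dimethoxyphenyl in place of 4-methylphenyl on a saturated chain carbon bound to an amide-type nitrogen. Going by the values given here, none of the measured steps touches a methoxy group on this side of the molecule; they only move or extend a methyl, and each of them was small. On that basis the step from compound 3 to compound 4 is expected to be a 1.2-fold lower number from compound 3 to compound 4 (0.06 log units; within the scatter), with no firm direction. Compound 4 is therefore estimated at 80000 nM in this assay, within a range from 30000 nM to 200000 nM.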

Compound 4, half-maximal inhibitory concentration: > 100000 nM
Compound 4 gave a limit, no number; the forecaster's own chance of this, stated with the estimate: 35%; middle value at least 1.2-fold (0.09 log units) away from the limit.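

Putting 3,4-dimethoxybenzyl in place of 4-methylbenzyl on the amide-type nitrogen brought no measurable gain: for compound 4 the reading in this assay is a limit of the assay and not a number, > 100000 nM. The swap of the ring substituents gives only an at least 1.0-fold higher number from compound 3 to compound 4 (0.03 log units; that floor lies within the scatter), so no direction can be claimed for it, and the added methoxy groups leave this benzyl compound no closer to the phenyl amide. The comparison with that phenyl amide is clearer, with an at least 2.3-fold higher number from compound 2 to compound 4 (0.36 log units; beyond the scatter), so among the compounds with a number or a usable floor, compound 2 keeps the lowest reading. The step joining compound 1 and compound 4 cannot be read, and the series now presses against a single ceiling: the limit of > 100000 nM in this assay, at which 2 of the 4 values shown sit.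

The compounds shown leave open whether 3,4-dimethoxyphenyl placed on the amide-type nitrogen without the extra chain carbon would read like compound 2, and whether one methoxy group would read differently from two. They also say nothing of how an amine, a carboxylic acid or a longer chain would read at this place.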